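The source may report more compounds than this note shows. Statements on the series, on what has been measured and on what is new or still open speak of the compounds shown alone.

Measured compounds:
- compound 1, `CC(O)(CSc1ccc(C(F)(F)F)cc1)C(=O)Nc1ccc(S(F)(F)(F)(F)F)cc1`: 17000 nM
- compound 2, `CC(O)(CSc1ccc(OC(F)(F)F)cc1)C(=O)Nc1ccc(S(F)(F)(F)(F)F)cc1`: 16100 nM
- compound 3, `CC(O)(COc1cccc(C(F)(F)F)c1)C(=O)Nc1ccc(S(F)(F)(F)(F)F)cc1`: 24700 nM

All three were tested in a functional assay on LNCaP cells (Homo sapiens) for antiproliferative activity, read by propidium iodide staining, with a stated time of 96 h; on this read-out lower numbers stand for stronger inhibition and higher numbers for weaker inhibition. Compound 1 gives 17000 nM in this assay, compound 2 gives 16100 nM, and compound 3 gives 24700 nM. Compound 3 shows the highest of the three numbers, but each of its two gaps to the others is within the scatter, so no order among them can be read from these numbers.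

Compounds 1 and 2 differ in one place only: trifluoromethoxy in place of trifluoromethyl on an aromatic carbon. The step between them, a 1.1-fold lower number from compound 1 to compound 2 (0.02 log units; within the scatter), is within the scatter, so this change left the read-out essentially unmoved on the core of compound 1.

Compound 4, `CC(O)(COc1cccc(OC(F)(F)F)c1)C(=O)Nc1ccc(S(F)(F)(F)(F)F)cc1`, has not yet been measured. It differs from compound 3 by trifluoromethoxy in place of trifluoromethyl on an aromatic carbon. The cores of compound 1 and compound 3 differ in more than one place, and the difference between them is not broken down here. The change from compound 3 to compound 4 is the same kind of change as that from compound 1 to compound 2, not the same: in the first pair the group sits para to a large group, in the second pair it sits meta to a large group.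

For compound 4 a step of a 1.1-fold lower number from compound 3 to compound 4 (0.03 log units; within the scatter) is expected, resting on the small step of a 1.1-fold lower number from compound 1 to compound 2 (0.02 log units; within the scatter) seen for the same kind of change. Compound 4 is therefore estimated at 23000 nM in this assay, with a likely range from 11000 nM to 48000 nM.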

Compound 4, half-maximal inhibitory concentration: 11000 nM
For compound 4 the middle estimate is 2.1-fold (0.32 log units) above the measured one; low and high end bracket the measured number.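

In this assay, trifluoromethoxy in place of trifluoromethyl on the core of compound 3, meta to a large group, gives a 2.2-fold lower number from compound 3 to compound 4 (0.35 log units; beyond the scatter), so on this core the swap moves the read-out by a modest but real amount. Set beside the same swap on the core of compound 1, where the step stayed within the scatter, the two results still cannot be told apart: the same change on two cores in this assay, a 1.1-fold lower number (0.02 log units; within the scatter) from compound 1 to compound 2 and a 2.2-fold lower number (0.35 log units; beyond the scatter) from compound 3 to compound 4, 2.1-fold (0.33 log units) apart, within the scatter of two such steps. Among these compounds, this does not show that the swap behaves differently on the two cores, nor does it prove that it behaves alike, since there are only two pairs and these cores differ in more than one place, so a step seen on one core gives only a rough guide to the step on the other.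

What the compounds shown leave open is how a nitrile or a chlorine on the same aromatic carbon would compare with trifluoromethyl and trifluoromethoxy in this assay. On these data alone, it also remains open how the read-out would respond to changes elsewhere in the shared structure, such as an amine in place of the hydroxyl group.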